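Swapping an Aryl Sulfone in a Quinoline Series

The source may hold more compounds than are shown below. What is called first, only, known or untested is meant among the compounds shown, and "the series" means these compounds.

Four compounds share one core, a quinoline bearing an aryl group and an aryl sulfone. Compound 1 `COc1cccc(-c2c(S(=O)(=O)c3ccc(OC)c(Cl)c3)cnc3cc(F)ccc23)c1` carries a 3-chloro-4-methoxyphenyl on the sulfonyl sulfur and a 3-methoxyphenyl on the core. In an ADME assay on microsomes from liver (Homo sapiens) for metabolic stability, tested at 2.5 uM (on this read-out lower numbers stand for slow clearance and higher numbers for fast clearance), compound 1 gives 1.71 mL/min. Compound 2 `COc1cccc(-c2c(S(=O)(=O)c3cc(F)cc(F)c3)cnc3cc(F)ccc23)c1` differs from compound 1 by 3,5-difluorophenyl in place of 3-chloro-4-methoxyphenyl on a sulfonyl sulfur, and in this assay compound 2 gives 1.81 mL/min, a step of a 1.1-fold higher number from compound 1 to compound 2 (0.02 log units; within the scatter). Compound 3 `COc1ccc(S(=O)(=O)c2cnc3cc(F)ccc3c2-c2cccc(F)c2)cc1Cl` differs from compound 1 by fluoro in place of methoxy on an aromatic carbon; in this assay compound 3 gives 2.08 mL/min, a step of a 1.2-fold higher number from compound 1 to compound 3 (0.09 log units; within the scatter). All three numbers lie within the usual scatter of one another, so no ordering among them can be claimed.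

Compound 4 `O=S(=O)(c1cc(F)cc(F)c1)c1cnc2cc(F)ccc2c1-c1cccc(F)c1` has not yet been measured. It differs from compound 3 by 3,5-difluorophenyl in place of 3-chloro-4-methoxyphenyl on a sulfonyl sulfur. Among the measured compounds shown here, this is the same change as the one from compound 1 to compound 2, made on the same place and with the same surroundings, only on a core that carries fluoro rather than methoxy on its other aryl ring.

The expectation for compound 4 is therefore a step of about a 1.1-fold higher number from compound 3 to compound 4 (0.02 log units; within the scatter), because the earlier instance of this change gave a 1.1-fold higher number from compound 1 to compound 2 (0.02 log units; within the scatter). Compound 4 is estimated at 2.2 mL/min in this assay, with a likely range from 1.3 mL/min to 3.6 mL/min.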

Compound 4, intrinsic clearance in a liver preparation (reported as CLH), per the amount of preparation that the assay uses: 0.06 mL/min
Compound 4: middle estimate off by 37-fold (1.56 log units), on the high side, outside the stated range (below it).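

In this assay, 3,5-difluorophenyl in place of 3-chloro-4-methoxyphenyl on the sulfonyl sulfur gives a 35-fold lower number from compound 3 to compound 4 (1.54 log units; beyond the scatter), so a change that made no readable difference on the core of compound 1 behaves very differently on the core of compound 3: the same change on two cores in this assay, a 1.1-fold higher number (0.02 log units; within the scatter) from compound 1 to compound 2 and a 35-fold lower number (1.54 log units; beyond the scatter) from compound 3 to compound 4, 37-fold (1.56 log units) apart, beyond the scatter of two such steps. Seen from the other side, fluoro in place of methoxy on an aromatic carbon gives a 30-fold lower number from compound 2 to compound 4 (1.48 log units; beyond the scatter), and this change too depends on its surroundings: the same change on two cores in this assay, a 1.2-fold higher number (0.09 log units; within the scatter) from compound 1 to compound 3 and a 30-fold lower number (1.48 log units; beyond the scatter) from compound 2 to compound 4, 37-fold (1.56 log units) apart, beyond the scatter of two such steps. The two changes therefore do not simply add up in this series, since only compound 4, which carries both, stands apart from the other three; but one set of four compounds cannot show why this happens, or whether it would happen on any other core.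

On these data alone, it remains open whether the low number needs exactly this pairing of 3,5-difluorophenyl and fluoro, or whether other groups on the sulfonyl sulfur would give it too. A nitrile or an amine in place of that fluoro, for example, would show how narrow the requirement is.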